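From amino to nitro: a step into the unknown

This account rests on a few compounds, and the source may have more. Where it says the series, first, only, none or still open, it means among the compounds named here.

In a functional assay on the whole organism with Mus musculus as the target (a lower number here means that less compound is needed, a higher number that more compound is needed for the effect), compound 3 `COc1cc2c(cc1OC)C(c1ccc(N)cc1)=NN(C)C(=S)C2` gives 29.8 umol/kg and compound 2 `COc1cc2c(cc1OC)C(c1ccccc1)=NN(C)C(=S)C2` gives 30.6 umol/kg. The two share the low end of the three numbers, since a 1.0-fold lower number from compound 2 to compound 3 (0.01 log units; within the scatter) stays within the scatter. Compound 1 `COc1cc2c(cc1OC)C(c1ccc(Br)cc1)=NN(C)C(=S)C2` stands apart at 105 umol/kg. Compound 4 `COc1cc2c(cc1OC)C(c1ccc([N+](=O)[O-])cc1)=NN(C)C(=S)C2` carries nitro in place of amino on an aromatic carbon. Three measured swaps at this place bear on it: a 3.4-fold lower number from compound 1 to compound 2 (0.54 log units; beyond the scatter) and a 3.5-fold lower number from compound 1 to compound 3 (0.55 log units; beyond the scatter) are modest, while a 1.0-fold lower number from compound 2 to compound 3 (0.01 log units; within the scatter) shows no real change. Nitro itself is untested, and it could fall near either level. A small rise is therefore expected, and the expected step is a 2.2-fold higher number from compound 3 to compound 4 (0.34 log units; beyond the scatter). The estimate for compound 4 is 65 umol/kg, with an expected range from 22 umol/kg to 170 umol/kg.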

Compound 4, dose for half-maximal effect: 103 umol/kg
The estimate for compound 4 lay 1.6-fold (0.20 log units) below the measured number; the measured number falls inside the stated range.
By their numbers in this assay, from the lowest: compounds 3 and 2 (each within the scatter of the next); then compounds 4 and 1 (each within the scatter of the next).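

In this assay, nitro lands with bromo, showing a 1.0-fold lower number from compound 1 to compound 4 (0.01 log units; within the scatter), and apart from the other two groups, showing a 3.5-fold higher number from compound 3 to compound 4 (0.54 log units; beyond the scatter) and a 3.4-fold higher number from compound 2 to compound 4 (0.53 log units; beyond the scatter). The higher level of compound 1 is therefore not unique to bromo: two different groups on this aromatic carbon now share it, while amino and hydrogen share the lower level. Nothing available explains this pairing. Still open, from the compounds shown here alone, is where methoxy, a carboxylic acid or a longer chain would fall on this aromatic carbon, and whether any group would give a number outside these two levels.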